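The compounds below may be only part of what the source reports. "The series", "measured", "known", "first", "only" and "open" are said of these compounds alone.

Within the data shown here, compound 2 `NC(=O)c1cc(Cl)c2c(Cl)c(C#CCN3CCCC3=O)n([C@H]3CCCNC3)c2n1` sits at the top of the two numbers known so far: in a functional assay on KG-1 cells (Homo sapiens) for antiproliferative activity (on this read-out higher numbers stand for an effect only at larger amounts of compound and lower numbers for an effect already at smaller amounts), compound 2 gives 178 nM, while compound 1 `NC(=O)c1cc(Cl)c2c(Cl)c(C#CC3CCOCC3)n([C@H]3CCCNC3)c2n1` gives 69 nM. Among the measured compounds shown here, the single step between them, a 2.6-fold higher number from compound 1 to compound 2 (0.41 log units; beyond the scatter), is the only measured comparison available, and it concerns a different swap at the same triple-bonded carbon.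

Compound 3 `CC(C)(CC#Cc1c(Cl)c2c(Cl)cc(C(N)=O)nc2n1[C@H]1CCCNC1)C(N)=O` is made from compound 2 by one change: 1-carbamoyl-1-methylethyl in place of 2-oxopyrrolidin-1-yl on a saturated chain carbon bound to a triple-bonded carbon. For the measured compounds named here, no measured step covers this kind of exchange, so there is no direct guide to its direction. Going by the values given here, the one known step showed that altering the group on the triple-bonded carbon moves the number by a modest amount, and a change of similar size in either direction is the most that the data support here. A step from compound 2 to compound 3 of about a 1.1-fold lower number from compound 2 to compound 3 (0.05 log units; within the scatter) is therefore expected, with no clear direction favoured. Compound 3 is estimated to give 160 nM, within a range from 50 nM to 500 nM.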

Compound 3, half-maximal effective concentration: 269 nM
The estimate for compound 3 lay 1.7-fold (0.23 log units) below the measured number, and the stated range covers the measured number.
By their numbers in this assay, from the lowest: compound 1; then compounds 2 and 3 (each within the scatter of the next).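

In this assay, the ring of 2-oxopyrrolidin-1-yl gives way to the open-chain 1-carbamoyl-1-methylethyl, with the same count of heavy atoms and one added hydrogen-bond donor, and the result is a 1.5-fold higher number from compound 2 to compound 3 (0.18 log units; within the scatter) on this saturated chain carbon bound to a triple-bonded carbon. At this place, then, these two groups cannot be told apart in this assay, although one has a ring and the other has none. The open-chain group also gives a 3.9-fold higher number from compound 1 to compound 3 (0.59 log units; beyond the scatter) when the comparison is made with oxan-4-yl on the triple-bonded carbon, so compound 3 joins compound 2 in standing apart from compound 1, and no measurement on these compounds offers a reason for these numbers.

Going by these compounds, it remains open whether the amide hydrogens or the branched carbon that holds the carbamoyl group matter more, since these two features enter together. A carboxylic acid or a dimethylamino group on the same saturated chain carbon, or a longer chain leading to the carbamoyl group, would show how much variation this place tolerates.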